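Sulfonyl variation at the sulfonamide: compound 3 to compound 4

This account rests on a few compounds, and the source may have more. Where it says the series, first, only, none or still open, it means among the compounds named here.

In an assay on HEK293 cells for inhibition of prostaglandin E2 receptor EP2 subtype (Rattus norvegicus) (a lower number here means a stronger inhibitor, a higher number a weaker inhibitor), compound 1 `CC(C)(C)c1ccc(CN(Cc2cccc(CCC(=O)O)c2)S(=O)(=O)c2ccccc2)cc1` gives 278 nM. Compound 3 `CC(C)(C)c1ccc(CN(Cc2cccc(CCC(=O)O)c2)S(C)(=O)=O)cc1` gives 379 nM in this assay, which is the highest of the two plain numbers, though its gap to compound 1, a 1.4-fold higher number from compound 1 to compound 3 (0.13 log units; within the scatter), is within the scatter. Compound 2 `CC(C)(C)c1ccc(CN(Cc2cccc(CCC(=O)O)c2)S(=O)(=O)c2ccc(Cl)cc2)cc1` reports only a limit in this assay, > 3200 nM, which is the limit of > 3200 nM in this assay, at which 1 of the 3 values shown sits. The resulting steps are an at least 11-fold higher number from compound 1 to compound 2 (1.06 log units; beyond the scatter) and an at least 8.4-fold lower number from compound 2 to compound 3 (0.92 log units; beyond the scatter).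

Compound 4 `CC(C)(C)c1ccc(CN(Cc2cccc(CCC(=O)O)c2)S(=O)(=O)c2ccccn2)cc1` is to be measured in this assay. It differs from compound 3 by pyridin-2-yl in place of methyl on a sulfonyl sulfur. The step that bears on this is the exchange of the group on the sulfonyl sulfur between compound 1 and compound 3, a 1.4-fold higher number from compound 1 to compound 3 (0.13 log units; within the scatter), where phenyl and methyl gave numbers within the scatter of each other. The step to compound 2, an at least 11-fold higher number from compound 1 to compound 2 (1.06 log units; beyond the scatter), shows that a substituted aromatic ring on the sulfonyl sulfur can shift the number strongly, but pyridin-2-yl carries no such substituent, so a small step is expected.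

From compound 3 to compound 4 the expected step in this assay is a 1.2-fold lower number from compound 3 to compound 4 (0.07 log units; within the scatter). For compound 4 the estimated value in this assay is 320 nM, with a range from 110 nM to 1400 nM.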

Compound 4, half-maximal inhibitory concentration: 52 nM
Compound 4: middle estimate off by 6.2-fold (0.79 log units), on the high side; measured number outside the range, below it.
By their numbers in this assay, from the lowest: compound 4; then compounds 1 and 3 (each within the scatter of the next). At a limit, above all of these: compound 2.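

The sulfonyl sulfur position is not indifferent to its group in this assay: phenyl and methyl could not be told apart, but pyridin-2-yl separates from both, with a 5.3-fold lower number from compound 1 to compound 4 (0.73 log units; beyond the scatter) and a 7.3-fold lower number from compound 3 to compound 4 (0.86 log units; beyond the scatter). Going by these compounds alone, the first of these two steps is the sharper comparison, since an aromatic six-membered ring stays in place and only phenyl gives way to pyridin-2-yl, so an aromatic ring on this sulfur can move the number down as well as up, and the earlier compounds showed only the upward move. The aromatic groups on this sulfur now span an at least 61-fold lower number from compound 2 to compound 4 (1.78 log units; beyond the scatter), a step that is itself bounded, compound 2 being reported only at a limit: the limit of > 3200 nM in this assay, at which 1 of the 4 values shown sits.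

The compounds shown leave open whether the lower number of compound 4 is tied to pyridin-2-yl itself or would also come with pyridin-3-yl, pyridin-4-yl or a pyrimidin-2-yl group on the sulfonyl sulfur. They also do not tell whether chloro on the pyridin-2-yl ring would cost as much as it does on phenyl, where the step is an at least 11-fold higher number from compound 1 to compound 2 (1.06 log units; beyond the scatter).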